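A few compounds are considered here, and "the series" means these few. Any claim that something is new, unique, unknown or untested is made for them only; others in the source may bear on it.

Measured so far:
Compound 1, `COc1cnc(-c2ccccn2)nc1NCc1ccccc1C`: 220 nM
Compound 2, `COc1cnc(-c2ccccn2)nc1C1CCCC1`: 1800 nM

The account follows the step from compound 2 to compound 3. In a functional assay on RAW264.7 cells (Mus musculus), with a stated time of 3 days (on this read-out lower numbers stand for stronger inhibition and higher numbers for weaker inhibition), compound 1 gives 220 nM, whereas compound 2 gives 1800 nM, the highest of the two numbers; the gap between them lies beyond the usual scatter, so compound 2 stands as the weaker of the pair on this read-out. Among the measured compounds shown here, no pair of measured compounds differs in a single place, so no measured step is available to lean on.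

Compound 3, `COc1cnc(-c2ccccn2)nc1NCCCC(=O)O`, departs from compound 2 as follows: (3-carboxypropyl)amino in place of cyclopentyl on an aromatic carbon. Compound 1 shares with compound 3 an amino-linked substituent at this position, but its substituent is a different one, so no direct reading of the new group can be taken from it. On that thin basis the step from compound 2 to compound 3 is expected to be small, a 1.7-fold higher number from compound 2 to compound 3 (0.22 log units; within the scatter), most likely toward a somewhat higher number, though a result within the scatter would not surprise. The estimate for compound 3 in this assay is 3000 nM, with a range from 700 nM to 15000 nM.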

Compound 3, half-maximal inhibitory concentration: > 10000 nM
Compound 3: only a limit was reported; the forecaster's own chance of this, stated with the estimate: 15%; at least 3.3-fold (0.52 log units) between middle value and limit.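

In this assay, compound 3 reached only a limit of the assay, not a number: the limit of > 10000 nM in this assay, at which 1 of the 3 values shown sits.

Even read as a limit, the replacement of cyclopentyl by (3-carboxypropyl)amino gives an at least 5.5-fold higher number from compound 2 to compound 3 (0.74 log units; beyond the scatter), the first measured single-place step at this aromatic carbon, and it shows that the result on this read-out depends on the group placed here. With the amino link kept, 2-carboxyethyl in place of 2-methylphenyl gives an at least 45-fold higher number from compound 1 to compound 3 (1.65 log units; beyond the scatter), so an amino link at this position does not by itself secure inhibition.

The compounds shown do not separate the contribution of the carboxylic acid from that of the chain carrying it, and a plain butylamino chain, a methyl ester or a primary amide on the same chain would be needed to tell the two apart. Also open, on these data alone, are how far the true value of compound 3 lies past its limit, and whether a shorter or longer chain ending in a carboxylic acid, or a chain ending in an amine, would give a similar result.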